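The source may hold more compounds than are shown below. What is called first, only, known or untested is meant among the compounds shown, and "the series" means these compounds.

Working notes on the series. Compound 1 `CC(=O)N1N=C(c2ccc(N3CCN(C)CC3)cc2)CC1c1ccc(N(C)C)cc1` gives -0.8% in a functional assay on HCC1806 cells (Homo sapiens) for inhibition, read by sulforhodamine B assay, tested at 10 uM; on this read-out higher numbers stand for more inhibition at the one concentration tested (going by the name of the read-out) and lower numbers for less inhibition. Compound 2 `CN1CCN(c2ccc(C3=NN(C(=O)CCCl)C(c4ccc(N(C)C)cc4)C3)cc2)CC1` differs from compound 1 by chloromethyl in place of hydrogen on a saturated chain carbon bound to a carbonyl carbon; in this assay compound 2 gives 1.7%, a step of a number 2.5 percentage points higher from compound 1 to compound 2 (within the scatter). Compound 3 `CC(=O)N1N=C(c2ccc(-n3cncn3)cc2)CC1c1ccc(N(C)C)cc1` differs from compound 1 in its core by 1H-1,2,4-triazol-1-yl in place of 4-methylpiperazin-1-yl on an aromatic carbon; compound 3 gives 11%, a step of a number 11.8 percentage points higher from compound 1 to compound 3 (beyond the scatter). Compound 4 `CN(C)c1ccc(C2CC(c3ccc(-n4cncn4)cc3)=NN2C(=O)CCCl)cc1` is not yet measured; it differs from compound 3 by chloromethyl in place of hydrogen on a saturated chain carbon bound to a carbonyl carbon, the same change as that from compound 1 to compound 2, made on the core of compound 3. Since that change gave a number 2.5 percentage points higher from compound 1 to compound 2 (within the scatter), a step of about a number 2 percentage points higher from compound 3 to compound 4 (within the scatter) is expected here, resting on that single prior instance. Compound 4 is therefore estimated at 13%, with the plausible range 3% to 23%.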

Compound 4, a percentage reported as inhibition, at one concentration (the size of the read-out at that concentration, not a potency): -3.4%
The estimate for compound 4 lay 16.4 percentage points above the measured number, outside the stated range (below it).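

Chloromethyl in place of hydrogen on a saturated chain carbon bound to a carbonyl carbon gives a number 14.4 percentage points lower from compound 3 to compound 4 (beyond the scatter), and in this assay this change does not carry over unchanged from one core to the other: the same change on two cores in this assay, a number 2.5 percentage points higher (within the scatter) from compound 1 to compound 2 and a number 14.4 percentage points lower (beyond the scatter) from compound 3 to compound 4, 16.9 percentage points apart, beyond the scatter of two such steps. Read the other way, 1H-1,2,4-triazol-1-yl in place of 4-methylpiperazin-1-yl gives a number 5.1 percentage points lower from compound 2 to compound 4 (within the scatter), and the size and direction of that change also differ with the acyl group present: the same change on two cores in this assay, a number 11.8 percentage points higher (beyond the scatter) from compound 1 to compound 3 and a number 5.1 percentage points lower (within the scatter) from compound 2 to compound 4, 16.9 percentage points apart, beyond the scatter of two such steps. Both comparisons rest on the same four compounds and describe one mismatch seen from two sides; they give no cause and no rule for any other core.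

On these data alone, it remains open whether an amine in place of the chlorine, or a longer chain on the carbonyl, would follow acetyl or (2-chloroethyl)carbonyl on these two cores.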